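Extending the Aryl Side Chain of a Cyclohexyl Carbamate

This account rests on a few compounds, and the source may have more. Where it says the series, first, only, none or still open, it means among the compounds named here.

Three carbamates have been measured in an assay on membranes from brain for inhibition of Fatty-acid amide hydrolase 1 (Rattus norvegicus); on this read-out higher numbers stand for weaker inhibition and lower numbers for stronger inhibition. Compound 2 `Cc1cccc(OC(=O)NC2CCCCC2)c1` gives 808 nM, the highest of the three numbers. Compound 1 `CCCCNC(=O)Oc1ccc(OCc2ccccc2)cc1` gives 390 nM and compound 3 `O=C(NC1CCCCC1)Oc1ccc2cccc(Br)c2c1` gives 174 nM, both lower than compound 2 by more than the scatter. Compound 4 `CCCCCc1cccc(OC(=O)NC2CCCCC2)c1` has not been measured; it differs from compound 2 by butyl in place of hydrogen on a saturated chain carbon bound to an aromatic carbon. Within the data shown here, no measured pair shares this single change, so the expectation rests on the three values alone. Because compound 1 gives 390 nM and compound 3 gives 174 nM while carrying larger groups than the methyl of compound 2, compound 4 is expected to reach a lower number. The step of a 4.0-fold lower number from compound 2 to compound 4 (0.61 log units; beyond the scatter) is expected to go beyond the scatter. Compound 4 is estimated at 200 nM, within a range from 60 nM to 650 nM.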

Compound 4, half-maximal inhibitory concentration: 188 nM
Beside the measured number, compound 4's estimate is 1.1-fold (0.03 log units) above it; measured number inside the range.
By their numbers in this assay, from the lowest: compounds 3 and 4 (each within the scatter of the next); then compound 1; then compound 2.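

In this assay, among these compounds, the change from methyl to pentyl at this position gives a 4.3-fold lower number from compound 2 to compound 4 (0.63 log units; beyond the scatter), a modest step and the first single-place comparison. It shows that a saturated chain carbon bound to an aromatic carbon can carry butyl in place of hydrogen with stronger inhibition, not weaker. No measured evidence accounts for this step. Going by these compounds, whether inhibition keeps improving with a chain longer than pentyl stays open. So does the outcome of ending that chain in an amine or a carboxylic acid.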